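Cytotoxicity of a Carboxyphenyl Analogue of Compound 1

This account rests on a few compounds, and the source may have more. Where it says the series, first, only, none or still open, it means among the compounds named here.

Within the data shown here, compound 1 `COc1ccc(Cn2ccc3ccc(Cc4cccc(C(=O)O)c4)cc32)cc1` holds the only numerical value in an ADME assay on HL2/3 cells (Homo sapiens) for cytotoxicity, read by XTT assay, with a stated time of 24 h; a lower number here means that less compound is tolerated, a higher number that more compound is tolerated: compound 1 gives 100000 nM. Compound 2 `O=C(O)c1cccc(Cc2ccc3ccn(Cc4cccc(C(=O)O)c4)c3c2)c1` reaches only a limit of the assay, and in this assay compound 2 gives > 200000 nM, which is the limit of > 200000 nM in this assay, at which 1 of the 2 values shown sits. The step of an at least 2.0-fold higher number from compound 1 to compound 2 (0.30 log units; that floor lies within the scatter) is thus itself a floor. Compound 3 `O=C(O)c1cccc(Cc2ccc3ccn(-c4cccc(C(=O)O)c4)c3c2)c1` alters compound 1 by 3-carboxyphenyl in place of 4-methoxybenzyl on an aromatic nitrogen. Among the measured compounds shown here, the only measured step bearing on this also brings in 3-carboxyphenyl, so a rise of similar or greater size is expected, a 1.8-fold higher number from compound 1 to compound 3 (0.26 log units; within the scatter). Compound 3 is therefore estimated at 180000 nM, between 70000 nM and 400000 nM.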

Compound 3, half-maximal cytotoxic concentration: > 400000 nM
Compound 3 was reported as a limit (the forecaster's own chance of this, stated with the estimate: 55%); middle value at least 2.2-fold (0.34 log units) from the limit.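

In this assay, the change on the aromatic nitrogen now gives a step that stands clear of the scatter: an at least 4.0-fold higher number from compound 1 to compound 3 (0.60 log units; beyond the scatter). The earlier step, an at least 2.0-fold higher number from compound 1 to compound 2 (0.30 log units; that floor lies within the scatter), did not show this. Compound 3 stands at a limit and not at a number, so this step is also only a floor: the limit of > 400000 nM in this assay, at which 1 of the 3 values shown sits.

Compound 2 and compound 3 both stand at limits, so they cannot be read against each other. On these data alone, it stays open whether the rise needs the carboxylic acid itself, or whether an amine in its place would also give it.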